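Thiophene sulfonyl in place of dienoyl on the threonine amide

The source may report more compounds than this note shows. Statements on the series, on what has been measured and on what is new or still open speak of the compounds shown alone.

Compound 1 `CCCCCCCCCCCCCCCCCCNC(=O)[C@@H](NC(=O)c1cccs1)[C@@H](C)O` gives 117000 nM in a functional assay on SiHa cells (Homo sapiens) for cytotoxicity, read by MTT assay, with a stated time of 48 h; on this read-out higher numbers stand for weaker inhibition and lower numbers for stronger inhibition. Compound 2 `C/C=C/C=C/C(=O)N[C@H](C(=O)NCCCCCCCCCCCCCCCCCC)[C@@H](C)O` reaches only the limit of > 200000 nM in this assay. From this the step of an at least 1.7-fold higher number from compound 1 to compound 2 (0.23 log units; that floor lies within the scatter) is known, its floor within the scatter. Compound 3 `CCCCCCCCCCCCCCCCCCNC(=O)[C@@H](NS(=O)(=O)c1cccs1)[C@@H](C)O` differs from compound 2 by (thiophen-2-yl)sulfonyl in place of (penta-1,3-dien-1-yl)carbonyl on an amine nitrogen. Within the data shown here, the only measured step that bears on it, an at least 1.7-fold higher number from compound 1 to compound 2 (0.23 log units; that floor lies within the scatter), ran the other way and had a floor within the scatter, so a drop of no more than the scatter is expected, an at least 1.3-fold lower number from compound 2 to compound 3 (0.12 log units; that floor lies within the scatter). Compound 3 is estimated at 150000 nM, between 60000 nM and 400000 nM, with a limit read-out still possible in this assay.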

Compound 3, half-maximal inhibitory concentration: > 200000 nM
Compound 3: only a limit was reported; the forecaster's own chance of this, stated with the estimate: 40%; middle value at least 1.3-fold (0.12 log units) away from the limit.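

With the thiophen-2-yl kept, replacing carbonyl by sulfonyl on the amine nitrogen gives an at least 1.7-fold higher number from compound 1 to compound 3 (0.23 log units; that floor lies within the scatter), so this floor does not separate the sulfonyl from the carbonyl in this assay. Compound 3 gives > 200000 nM, which is a limit and not a number, and the step from compound 2 cannot be read. Two different groups on this nitrogen now end at the same ceiling: the limit of > 200000 nM in this assay, at which 2 of the 3 values shown sit.

Going by these compounds, how far compound 2 and compound 3 lie beyond that limit stays open. Also open, on these data alone, is whether a carbonyl group bearing an amine or a carboxylic acid on this nitrogen would give a number rather than a limit.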